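Rearranging the sugar on a nitrobenzyl purine nucleoside

The source may hold more compounds than are shown below. What is called first, only, known or untested is meant among the compounds shown, and "the series" means these compounds.

Measured so far:
- compound 1, `CC(=O)c1cc(Cl)ccc1Sc1nc(N)nc2c1ncn2[C@@H]1O[C@H](CO)[C@@H](O)[C@H]1O`: 14500 nM
- compound 2, `O=[N+]([O-])c1ccc(CNc2ncnc3c2ncn3[C@H]2C[C@H](O)[C@@H](CO)O2)cc1`: 15.9 nM

Of the compounds shown here, two have been measured in an assay on isolated protein for binding affinity to Equilibrative nucleoside transporter 1 (Homo sapiens); on this read-out higher numbers stand for weaker inhibition and lower numbers for stronger inhibition. Compound 1 gives 14500 nM in this assay, and compound 2 gives 15.9 nM. Compound 2 thus gives the lower of the two numbers, and its gap to compound 1 is far beyond the usual scatter of repeated measurements; nothing beyond these two values is known about that pair.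

Compound 3, `C[C@H]1O[C@@H](n2cnc3c(NCc4ccc([N+](=O)[O-])cc4)ncnc32)[C@H](O)[C@@H]1O`, has not yet been measured. It shares every atom with compound 2, joined differently: 3,4-dihydroxy-5-methyloxolan-2-yl in place of 4-hydroxy-5-(hydroxymethyl)oxolan-2-yl on an aromatic nitrogen. The purine part and its nitrobenzylamino group are unchanged; only the sugar is rearranged.

For the measured compounds named here, no measured pair shows what such a sugar rearrangement does here, so the expectation rests on compound 2 alone. Because compound 2 gives 15.9 nM and the sugar change moves one hydroxyl rather than removing a group, compound 3 is expected to land within a modest step, a 1.9-fold higher number from compound 2 to compound 3 (0.28 log units; within the scatter), which may fall inside the scatter. The estimate for compound 3 in this assay is 30 nM, with a range from 8 nM to 120 nM.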

Compound 3, half-maximal inhibitory concentration: 21.9 nM
For compound 3 the middle estimate is 1.4-fold (0.14 log units) above the measured one; the range from low to high includes it.
By their numbers in this assay, from the lowest: compounds 2 and 3 (each within the scatter of the next); then compound 1.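

In this assay, for the compounds shown here, putting 3,4-dihydroxy-5-methyloxolan-2-yl in place of 4-hydroxy-5-(hydroxymethyl)oxolan-2-yl on an aromatic nitrogen gives a 1.4-fold higher number from compound 2 to compound 3 (0.14 log units; within the scatter) and thus provides the first comparison here of compounds differing in one place. On this read-out the two sugars cannot be told apart, even though they have the same counts of heavy atoms, hydrogen-bond donors and hydrogen-bond acceptors and differ in their defined stereocentres. No measurement available here explains why the two sugars read alike.

From the compounds shown here alone, compounds 2 and 3 cover only these two arrangements of the same atoms, so it remains open whether the sugar can carry a quite different group, such as an amine or a carboxylic acid, in place of the methyl or hydroxymethyl group. Going by these compounds, compound 1 differs from both in more than one place, so it cannot show what the sugar change does on its own, and the role of the nitro group on the benzyl ring also remains untested by any comparison here, for example against a nitrile.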